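Removing the methoxy group from compound 1

This account rests on a few compounds, and the source may have more. Where it says the series, first, only, none or still open, it means among the compounds named here.

Compound 1 `COc1ccc(-c2nc3sc(-c4ccccc4)cn3n2)cc1`: 81%
Compound 2 `COc1cc(-c2nc3sc(-c4ccccc4)cn3n2)cc(OC)c1OC`: 35%

In a functional assay on MDA-MB-468 cells (Homo sapiens) for inhibition, read by sulforhodamine B assay, with a stated time of 48 h, tested at 10 uM (a higher number here means more inhibition of growth at the concentration tested, a lower number less inhibition of growth), compound 1 stands highest of the two measured compounds, and its lead over compound 2 lies beyond the usual scatter. The unmeasured compound 3 `c1ccc(-c2nc3sc(-c4ccccc4)cn3n2)cc1` differs from compound 1 in one place, with hydrogen in place of methoxy on an aromatic carbon, para to a large group hydrogen in place of methoxy on an aromatic carbon and the shared core unchanged.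

Within the data shown here, no two measured compounds differ in one place only, so no direct step guides this change. Compound 2 carries more methoxy groups and reads 35% in this assay while compound 1 reads 81% there, so these two show that more methoxy groups need not bring more inhibition. Even so, compound 1 at 81% has far more room to fall than to rise, and a moderate drop beyond the scatter is expected. The expected change is a number 23 percentage points lower from compound 1 to compound 3 (beyond the scatter) and rests on thin evidence. For compound 3 the estimated value is 58% with an expected range from 30% to 82% in this measurement.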

Compound 3, percent growth inhibition at one concentration: 14%
Compound 3: middle estimate off by 44 percentage points, on the high side; measured number below the stated range.
By their numbers in this assay, from the lowest: compound 3; then compound 2; then compound 1.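

In this assay, replacing the methoxy group with hydrogen on an aromatic carbon, para to a large group, gives a number 67 percentage points lower from compound 1 to compound 3 (beyond the scatter) with the shared core unchanged. Among these compounds, this is the first comparison in which only one place differs, so the drop in growth inhibition at the concentration tested can be tied to this single change, and it shows that the methoxy group at this position counts for much of the inhibition that compound 1 gives. No measurement is available to explain why removing this group has so large an effect.

As far as these compounds go, it remains open whether the methoxy group is needed as such, or whether a hydroxyl group, an ethoxy group, a chlorine atom or an amine on the same carbon would restore the inhibition. From the compounds shown here alone, it also remains open how far this large step holds with other groups on the rest of the molecule, since this single pair gives only one view of the position.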